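This account rests on a few compounds, and the source may have more. Where it says the series, first, only, none or still open, it means among the compounds named here.

Of the compounds shown here, two with a shared core have been measured so far in a toxicity assay on HUVEC cells (Homo sapiens) for inhibition; on this read-out higher numbers stand for weaker inhibition of growth and lower numbers for stronger inhibition of growth. Among the compounds with values here, compound 1 `Cc1nc(-c2ccccc2F)c(C(=O)N2CCN(c3cc(Cl)cc(Cl)c3)CC2)o1` gives 0.177 ug/mL and compound 2 `Cc1cc(C)cc(N2CCN(C(=O)c3oc(C)nc3-c3ccccc3)CC2)c1` gives 0.356 ug/mL and the two values lie within the usual scatter of each other, so compound 2 stands level with the only other number available. Compound 3 `COc1cc(OC)cc(N2CCN(C(=O)c3oc(C)nc3-c3ccccc3)CC2)c1` has not yet been measured. It differs from compound 2 in one place, with 3,5-dimethoxyphenyl in place of 3,5-dimethylphenyl on an amine nitrogen in a ring. Within the data shown here, no pair of measured compounds tests a change at this place, so no step beyond the scatter is expected in this assay from this exchange. The expected move is a 1.1-fold higher number from compound 2 to compound 3 (0.05 log units; within the scatter) and it is estimated to have no firm direction. Compound 3 is expected at 0.4 ug/mL with an estimated range from 0.15 ug/mL to 1 ug/mL as its likely span.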

Compound 3, concentration for 50% growth inhibition: 0.319 ug/mL
Beside the measured number, compound 3's estimate is 1.3-fold (0.10 log units) above it; measured number inside the range.
By their numbers in this assay, from the lowest: compounds 1, 3 and 2 (each within the scatter of the next).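

In this assay, putting 3,5-dimethoxyphenyl in place of 3,5-dimethylphenyl on the amine nitrogen in the ring gives a 1.1-fold lower number from compound 2 to compound 3 (0.05 log units; within the scatter). Within the data shown here, this is the first pair to test a change at this position, and it shows that the number stays level even though the entering group carries hydrogen-bond acceptors and the leaving group carries none. No evidence is at hand that bears on this result.

On these data alone, the pair covers only these two phenyl groups, so it remains open whether the number would stay level with a carboxylic acid or an amine on the phenyl ring. It also leaves open what a longer chain on the same nitrogen, in place of the phenyl ring, would do in this assay.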